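This account rests on a few compounds, and the source may have more. Where it says the series, first, only, none or still open, it means among the compounds named here.

Working notes on the series in an ADME assay on microsomes from liver (Mus musculus, strain CD1) for metabolic stability, read by HPLC, using NADPH, with a stated time of 30 min; on this read-out lower numbers stand for slow clearance and higher numbers for fast clearance. Of the compounds shown here, three sharing one core have been measured. Compound 1 `COc1cccc(NC(=O)c2nnn(Cc3ccc(-n4cccn4)cc3)c2N)c1` gives 2.3 mL.min-1.g-1. Compound 2 `COc1cccc(NC(=O)c2nnn(Cc3ccccc3)c2N)c1` gives 3.7 mL.min-1.g-1. Compound 3 `COc1cccc(NC(=O)c2nnn(Cc3ccc(C#N)cc3)c2N)c1` gives 2.5 mL.min-1.g-1. On these numbers compound 3 sits between the other two, but neither neighbour is separated from it by more than the scatter: a 1.1-fold higher number from compound 1 to compound 3 (0.04 log units; within the scatter) and a 1.5-fold lower number from compound 2 to compound 3 (0.17 log units; within the scatter) are both within it, as is a 1.6-fold higher number from compound 1 to compound 2 (0.21 log units; within the scatter).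

Compound 4 `COc1cccc(NC(=O)c2nnn(Cc3ccc(C4CC4)cc3)c2N)c1` is the next member, not yet measured. It differs from compound 3 by cyclopropyl in place of cyano on an aromatic carbon. All three measured steps bear on this position: each swapped the group on that aromatic carbon (hydrogen, cyano, 1H-pyrazol-1-yl), and none moved this assay beyond the scatter. Cyclopropyl itself has no precedent among the measured compounds, so the expectation rests only on the flatness seen so far. Compound 4 is therefore expected to show no step beyond the scatter, a 1.2-fold higher number from compound 3 to compound 4 (0.08 log units; within the scatter). The estimate for compound 4 is 3 mL.min-1.g-1, with a range from 1.5 mL.min-1.g-1 to 6 mL.min-1.g-1.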

Compound 4, intrinsic clearance in microsomes: 4.9 mL.min-1.g-1
For compound 4 the middle estimate is 1.6-fold (0.21 log units) below the measured one, and the stated range covers the measured number.
By their numbers in this assay, from the lowest: compounds 1, 3, 2 and 4 (each within the scatter of the next, the first and the last beyond it).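

In this assay, within the data shown here, the group on this aromatic carbon now shows an effect beyond the scatter for the first time, though a modest one (a 2.1-fold higher number from compound 1 to compound 4 (0.33 log units; beyond the scatter)), so the position is not entirely flat. That separation holds only between 1H-pyrazol-1-yl and cyclopropyl, since the cyclopropyl compound stays within the scatter of both the cyano compound (a 2.0-fold higher number from compound 3 to compound 4 (0.29 log units; within the scatter)) and the unsubstituted compound (a 1.3-fold higher number from compound 2 to compound 4 (0.12 log units; within the scatter)). Nothing available explains this difference in clearance.

Still open, on these data alone, is whether an amine, a carboxylic acid or a longer chain such as n-butyl on this aromatic carbon would stay within this narrow spread or extend it. The compounds shown also leave open whether cyclopropyl in place of 1H-pyrazol-1-yl would give a similar step on a different core.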